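Aryl ester swap: compound 3 to compound 4

The source may report more compounds than this note shows. Statements on the series, on what has been measured and on what is new or still open speak of the compounds shown alone.

Measured so far in a functional assay on CaEs17 cells (Homo sapiens) for cytotoxicity, read by MTT assay, with a stated time of 72 h (a higher number here means a weaker inhibitor, a lower number a stronger inhibitor), and shown with structures
compound 1 `C=C1C(=O)[C@@]23C(=O)OC[C@]4(C(=O)CCC(C)(C)[C@H]4C=O)[C@@H]2CC[C@@H]1[C@H]3O` gives 5850 nM
compound 2 `C=C1C(=O)[C@@]23C(=O)OC[C@]4(C(=O)CCC(C)(C)[C@H]4C=O)[C@@H]2CC[C@@H]1[C@H]3OC(C)=O` gives 1350 nM
compound 3 `C=C1C(=O)[C@@]23C(=O)OC[C@]4(C(=O)CCC(C)(C)[C@H]4C=O)[C@@H]2CC[C@@H]1[C@H]3OC(=O)c1ccc(OC)cc1` gives 2980 nM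

Compound 3 cannot be separated from compound 1, given a 2.0-fold lower number from compound 1 to compound 3 (0.29 log units; within the scatter) as the step between them. It does separate from compound 2, with a 2.2-fold higher number from compound 2 to compound 3 (0.34 log units; beyond the scatter) as a modest step toward weaker inhibition.

The next structure is compound 4 `C=C1C(=O)[C@@]23C(=O)OC[C@]4(C(=O)CCC(C)(C)[C@H]4C=O)[C@@H]2CC[C@@H]1[C@H]3OC(=O)c1ccc(F)cc1`, which has fluoro in place of methoxy on an aromatic carbon, para to a large group, with the count fluoro in place of methoxy on an aromatic carbon and nothing else altered.

Going by the values given here, no measured step changes a substituent on this aromatic ring, so the evidence is indirect. Changing the group on the oxygen gave a 4.3-fold lower number from compound 1 to compound 2 (0.64 log units; beyond the scatter) as the largest step, and even replacing methyl with 4-methoxyphenyl gave only a 2.2-fold higher number from compound 2 to compound 3 (0.34 log units; beyond the scatter) as a result. Both are modest, and the change here is smaller in kind, so no step beyond the scatter is expected in this assay. The estimated step is a 1.1-fold lower number from compound 3 to compound 4 (0.06 log units; within the scatter) in this case.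

For compound 4 the expected value is 2600 nM, with an estimated range from 1200 nM to 5500 nM overall.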

Compound 4, half-maximal inhibitory concentration: 8310 nM
The estimate for compound 4 lay 3.2-fold (0.50 log units) below the measured number; measured number above the stated range.
By their numbers in this assay, from the lowest: compound 2; then compounds 3, 1 and 4 (each within the scatter of the next, the first and the last beyond it).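

In this assay, going by these compounds alone, the substituent on the aromatic ring, para to a large group, proves to matter: fluoro in place of methoxy gives a 2.8-fold higher number from compound 3 to compound 4 (0.45 log units; beyond the scatter), the first measured change on this ring, so the aryl ester cannot be treated as a single unit. The size of the gap to the acetyl ester also depends on this substituent, with a 6.2-fold higher number from compound 2 to compound 4 (0.79 log units; beyond the scatter) being the largest step in the set, while the (4-fluorophenyl)carbonyl ester cannot be separated from the compound with hydrogen on that oxygen, given a 1.4-fold higher number from compound 1 to compound 4 (0.15 log units; within the scatter). No accompanying measurement bears on this result, and the numbers alone offer no explanation for it.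

Going by these compounds, with only methoxy and fluoro compared on this ring, it remains open whether the step follows a trend across substituents or is specific to this pair, and a chloro, an amine or a carboxylic acid at the same place would help to decide this. On these data alone, it is also open whether a longer chain in place of the acetyl methyl would keep compound 2's advantage over the other esters in this assay.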